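Swapping phenyl for benzyl on sulfur in two growth inhibitors

The compounds below may be only part of what the source reports. "The series", "measured", "known", "first", "only" and "open" are said of these compounds alone.

Of the compounds shown here, three have been measured in a functional assay on DU-145 cells (Homo sapiens) for inhibition, read by trypan blue exclusion, with a stated time of 96 h; on this read-out higher numbers stand for weaker inhibition of growth and lower numbers for stronger inhibition of growth. Compound 1, `O=C(/C(=C\c1ccccc1OCc1ccccc1)S(=O)(=O)c1ccc(F)cc1)c1ccc(Cl)cc1`, gives 1000 nM in this assay. Compound 2, `O=C(/C(=C\c1ccccc1OCc1ccccc1)S(=O)(=O)Cc1ccc(F)cc1)c1ccc(Cl)cc1`, carries 4-fluorobenzyl in place of 4-fluorophenyl on a sulfonyl sulfur, and in this assay compound 2 gives 10000 nM. That change produced a 10-fold higher number from compound 1 to compound 2 (1.00 log units; beyond the scatter). Compound 3, `Cc1ccc(/C=C(/Sc2ccc(F)cc2)C(=O)c2ccc(Cl)cc2)s1`, rests on a different core; the difference between the core of compound 1 and the core of compound 3 is not broken down here. In this assay compound 3 gives 25000 nM, the highest of the three numbers.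

Compound 4, `Cc1ccc(/C=C(/SCc2ccc(F)cc2)C(=O)c2ccc(Cl)cc2)s1`, has not yet been measured. It differs from compound 3 by 4-fluorobenzyl in place of 4-fluorophenyl on a sulfur. Among the measured compounds shown here, this is the same kind of change as the one from compound 1 to compound 2, but not the same: there the place was a sulfonyl sulfur, here it is a sulfur whose only other neighbour is a double-bonded chain carbon. Whether the step transfers from one core to the other is not known from these three compounds alone.

In this assay, for the measured compounds named here, compound 4 is expected to move by about a 4.0-fold higher number from compound 3 to compound 4 (0.60 log units; beyond the scatter), a step taken to be in the same direction as, and roughly the size of, the earlier one, because a 10-fold higher number from compound 1 to compound 2 (1.00 log units; beyond the scatter) is the only guide available. Compound 4 is thus estimated at 100000 nM in this assay, plausibly between 30000 nM and 400000 nM, with a real chance that the assay reports only a limit.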

Compound 4, concentration for 50% growth inhibition: > 100000 nM
Compound 4 gave a limit, no number (the forecaster's own chance of this, stated with the estimate: 40%); the middle value sits exactly at the limit.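

In this assay compound 4 gives > 100000 nM, which is a limit of the assay and not a number. Read against compound 3, 4-fluorobenzyl in place of 4-fluorophenyl gives an at least 4.0-fold higher number from compound 3 to compound 4 (0.60 log units; beyond the scatter), so the change moves the number the same way on a sulfonyl sulfur and on a sulfur whose other neighbour is a double-bonded chain carbon, and in both pairs growth inhibition weakens: the same change on two cores in this assay, a 10-fold higher number (1.00 log units; beyond the scatter) from compound 1 to compound 2 and an at least 4.0-fold higher number (0.60 log units; beyond the scatter) from compound 3 to compound 4; the limit leaves it open whether they differ. This shows that the direction of the step carries over between these two cores, but it does not show how large the step is on the core of compound 3, whether it matches the earlier step in size, or that it would hold on any further core: the limit of > 100000 nM in this assay, at which 1 of the 4 values shown sits.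

Left open is whether a sulfonyl sulfur on the core of compound 3 would give the same step as on the core of compound 1, a question that would separate the effect of the core from that of the sulfur. Also open, on these data alone, is what a longer chain, such as 2-(4-fluorophenyl)ethyl, would do on the sulfur of either core.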